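Stereochemical variation in an iminosugar alpha-galactosidase A series

The compounds below may be only part of what the source reports. "The series", "measured", "known", "first", "only" and "open" are said of these compounds alone.

For the measured compounds named here, compound 2, `NC[C@H]1NC[C@H](O)[C@H](O)[C@H]1O`, sits at the bottom of the two numbers measured so far: in an assay on isolated protein for inhibition of alpha-galactosidase A (Homo sapiens), read by fluorescence, tested at 100 uM (on this read-out lower numbers stand for less inhibition and higher numbers for more inhibition at the one concentration tested (going by the name of the read-out)), compound 2 gives 19%, whereas compound 1, `NC[C@@H]1NC[C@H](O)[C@@H](O)[C@H]1O`, gives 30% in this assay. Going by the values given here, the one measured step, a number 11 percentage points lower from compound 1 to compound 2 (beyond the scatter), rests on (the fact that compounds 1 and 2 differ only in the configuration as drawn); two ring stereocentres are drawn the other way round, and nothing else in the molecule moves.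

Compound 3, `NC[C@H]1NC[C@H](O)[C@@H](O)[C@H]1O`, has yet to be measured in this assay. It differs from compound 2 as follows: the two compounds have the same atoms and bonds and differ only in configuration as drawn: 1 of 4 stereo elements differ; a stereocentre at a saturated ring carbon is drawn S in compound 2 and R in compound 3. Among the compounds with values here, only the step from compound 1 to compound 2 bears on this change, and it involved two inverted centres rather than one, so it gives a rough scale but no firm direction. A single inversion of a ring stereocentre is therefore expected to move this assay by roughly the size of that step or less, in either direction, with a small shift back towards the number for compound 1 taken as the working assumption. For compound 3 the expected step is a number 6 percentage points higher from compound 2 to compound 3 (within the scatter). Compound 3 is therefore estimated at 25%, with a range from 8% to 45%.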

Compound 3, a percentage reported as inhibition, at one concentration (the size of the read-out at that concentration, not a potency): 99%
Compound 3: the middle estimate sits 74 percentage points below what was measured; measured number above the stated range.
By their numbers in this assay, from the lowest: compound 2; then compound 1; then compound 3.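

Compound 3 shows that inverting a single stereocentre at a saturated ring carbon can change the number in this assay far more than the earlier comparison suggested, with a number 80 percentage points higher from compound 2 to compound 3 (beyond the scatter) and a number 69 percentage points higher from compound 1 to compound 3 (beyond the scatter). Compounds 1 and 2 are each one inversion from compound 3, at different ring carbons, so the modest a number 11 percentage points lower from compound 1 to compound 2 (beyond the scatter) compares two compounds that both lie far below compound 3 and conceals how sharply the number depends on each of these two centres. No atom or bond enters or leaves in either new step, so configuration alone accounts for both: the fact that compounds 1 and 3 differ only in the configuration as drawn, and (the fact that compounds 2 and 3 differ only in the configuration as drawn).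

The series leaves open how the other ring stereocentres bear on the number, and how much potency lies behind the reading for compound 3, since a reading at one concentration is not a potency. It also leaves open whether the amine of the aminomethyl group matters, which a hydroxymethyl group or a longer chain in its place on the core of compound 3 would test.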